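The source may hold more compounds than are shown below. What is called first, only, known or untested is meant among the compounds shown, and "the series" means these compounds.

Compound 1 `CCOC(=O)/C=C/c1ccc2c(c1)C(=O)C(=O)N2Cc1ccc(OC)cc1` gives 10 nM
Compound 2 `COC(=O)/C=C/c1ccc2c(c1)C(=O)C(=O)N2Cc1ccccc1` gives 40 nM

In a functional assay on K562 cells (Homo sapiens) for cytotoxicity, read by MTT assay, with a stated time of 48 h (on this read-out higher numbers stand for weaker inhibition and lower numbers for stronger inhibition), compound 2 has the higher of the two numbers, with 40 nM standing beyond the usual scatter from the lower number of compound 1. Compound 3 `COC(=O)/C=C/c1ccc2c(c1)C(=O)C(=O)N2C` differs from compound 2 by hydrogen in place of phenyl on a saturated chain carbon bound to an amide-type nitrogen in a ring in a change that reads benzyl to methyl. Among the measured compounds shown here, no measured pair shows this change, so its size is a judgement: weaker inhibition is expected, by a step beyond the scatter. The expected step is a 13-fold higher number from compound 2 to compound 3 (1.10 log units; beyond the scatter) in that direction. For compound 3 the estimated value is 500 nM with 120 nM to 3000 nM as the expected range.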

Compound 3, half-maximal inhibitory concentration: 340 nM
For compound 3 the middle estimate is 1.5-fold (0.17 log units) above the measured one; low and high end bracket the measured number.
By their numbers in this assay, from the lowest: compound 1; then compound 2; then compound 3.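

In this assay, among the compounds shown here, the change from benzyl to methyl, hydrogen in place of phenyl on a saturated chain carbon bound to an amide-type nitrogen in a ring, gives an 8.5-fold higher number from compound 2 to compound 3 (0.93 log units; beyond the scatter), the only step here between compounds that differ in one place. It shows that this position responds to the change: losing the phenyl weakens inhibition, yet compound 3 still gives 340 nM in this assay. No measurement shown here explains this step. On these data alone, whether a longer chain or a cyclohexylmethyl group at this place would match compound 2 remains open.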